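Swapping iodomethyl for dibromomethyl on a brominated lactone core

The source may report more compounds than this note shows. Statements on the series, on what has been measured and on what is new or still open speak of the compounds shown alone.

The series rests on a shared brominated lactone core, tested in a functional assay on KB cells (Homo sapiens) for cytotoxicity; a lower number here means that less compound is needed, a higher number that more compound is needed for the effect. Compound 1 `CCC[C@@H](OC(C)=O)C1=C(Br)[C@@](CI)(OC)OC1=O` gives 2.4 ug/mL there. Compound 3 `CCC[C@@H](O)C1=C(Br)/C(=C/Br)OC1=O` gives 0.4 ug/mL in this assay, so compound 1 stands at the higher of the two numbers, a gap beyond the scatter. For compound 2 `CCCCC1=C(Br)/C(=C/Br)OC1=O` this assay reports only a limit, > 20 ug/mL, as noted in the limit of > 20 ug/mL in this assay, at which 1 of the 3 values shown sits. Among the measured compounds shown here, the one measured step, an at least 50-fold lower number from compound 2 to compound 3 (1.69 log units; beyond the scatter), concerns a different part of the molecule.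

Compound 4 `CCC[C@@H](OC(C)=O)C1=C(Br)[C@](OC)(C(Br)Br)OC1=O` differs from compound 1 at the saturated ring carbon that carries the halogenated one-carbon group: dibromomethyl in place of iodomethyl on a saturated ring carbon. For the measured compounds named here, no measured pair shows what exchanging one halogenated methyl group for another does here; the hydroxy-for-hydrogen step between compound 2 and compound 3 does not speak to it. With nothing to point either way, the expected step of no change at the digits printed from compound 1 to compound 4 (within the scatter) is none beyond the scatter. Compound 4 is therefore estimated at 2.4 ug/mL in this assay, with a range from 0.9 ug/mL to 6.5 ug/mL.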

Compound 4, concentration for half-maximal effect: 6.1 ug/mL
Compound 4: the middle estimate sits 2.5-fold (0.41 log units) below what was measured, within the range that was stated.
By their numbers in this assay, from the lowest: compound 3; then compound 1; then compound 4. At a limit, above all of these: compound 2.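

Among the compounds shown here, this is the first measured exchange at the saturated ring carbon that carries the halogenated one-carbon group. In this assay, dibromomethyl in place of iodomethyl gives a 2.5-fold higher number from compound 1 to compound 4 (0.41 log units; beyond the scatter), so the number responds to which halogenated methyl group sits here, yet compound 4 still gives a measured 6.1 ug/mL rather than a limit. Nothing measured here bears on why the number rises with this change.

From the compounds shown here alone, whether a plain methyl, a chloromethyl or a trifluoromethyl group on this ring carbon would give a lower or a higher number stays open. Also open, going by these compounds, is whether a bromomethyl group would behave like iodomethyl or like dibromomethyl, which would separate the kind of halogen from the number of halogens.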